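Swapping a Thiazole for Phenyl at the Weak End

The source may report more compounds than this note shows. Statements on the series, on what has been measured and on what is new or still open speak of the compounds shown alone.

The shared core of compound 3 `Clc1cc(Cl)cc(CO[C@H]2CCCN(Cc3nccs3)[C@H]2c2ccccc2)c1` carries, on a saturated chain carbon bound to an amine nitrogen in a ring, a 1,3-thiazol-2-yl group. In an assay on isolated protein for activation of cGMP-dependent protein kinase 1 (Homo sapiens), read by ADP-Glo, with stated times of 120 min and 40 min (on this read-out higher numbers stand for an effect only at larger amounts of compound and lower numbers for an effect already at smaller amounts), compound 3 gives only a limit of the assay, > 200000 nM, and no number. Two relatives with other groups at the same place have measured values: compound 1 `O=C(O)c1ccc(CN2CCC[C@H](OCc3cc(Cl)cc(Cl)c3)[C@@H]2c2ccccc2)s1` gives 76000 nM, and compound 2 `Clc1cc(Cl)cc(CO[C@H]2CCCN(Cc3ccc(-c4nn[nH]n4)cc3)[C@H]2c2ccccc2)c1` gives 74000 nM. The two measured steps that reach compound 3, an at least 2.6-fold higher number from compound 1 to compound 3 (0.42 log units; beyond the scatter) and an at least 2.7-fold higher number from compound 2 to compound 3 (0.43 log units; beyond the scatter), both run toward an effect only at larger amounts and both end at the limit of > 200000 nM in this assay, at which 1 of the 3 values shown sits.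

Compound 4 `Clc1cc(Cl)cc(CO[C@H]2CCCN(Cc3ccccc3)[C@H]2c2ccccc2)c1` differs from compound 3 by phenyl in place of 1,3-thiazol-2-yl on a saturated chain carbon bound to an amine nitrogen in a ring. Among the compounds with values here, no measured step covers this exact change; the group that enters has 0 hydrogen-bond donors and 0 hydrogen-bond acceptors, and neither the 5-carboxythiophen-2-yl of compound 1 nor the 4-(2H-tetrazol-5-yl)phenyl of compound 2 appears. Because compound 3 already stands at the limit of > 200000 nM in this assay, at which 1 of the 3 values shown sits, the step that the limit leaves unreadable from compound 3 to compound 4 is expected to be none beyond the scatter. Compound 4 is estimated at 250000 nM, within a range from 100000 nM to 700000 nM, and most likely it too is reported only as a limit.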

Compound 4, half-maximal effective concentration: > 200000 nM
Compound 4: a limit, no number; the forecaster's own chance of this, stated with the estimate: 70%; the middle value does not contradict the limit.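

Taking the 2H-tetrazol-5-yl group off compound 2, with hydrogen in its place on the aromatic carbon, gives an at least 2.7-fold higher number from compound 2 to compound 4 (0.43 log units; beyond the scatter), so in this assay the plain benzyl group does not keep the measurable effect seen with that group attached. Phenyl in place of 5-carboxythiophen-2-yl gives a matching result, an at least 2.6-fold higher number from compound 1 to compound 4 (0.42 log units; beyond the scatter), and among the four compounds shown, only those carrying the 2H-tetrazol-5-yl or the carboxyl group have a measured number, with no compound going against this. Compound 3 and compound 4 are each reported only as a limit, so the step between them cannot be read, and phenyl and 1,3-thiazol-2-yl cannot be ranked against each other at this position: the limit of > 200000 nM in this assay, at which 2 of the 4 values shown sit.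

As far as these compounds go, neither of the two measured compounds reaches beyond a weak effect, and how far below the limit compound 3 and compound 4 really lie stays unknown. From the compounds shown here alone, it also remains open whether a group of another kind on the same saturated chain carbon, such as a primary amine, a hydroxyl or a longer chain ending in a carboxylic acid, would give a measurable effect in this assay.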